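Methylsulfanyl in place of bromo: compound 3 to compound 4

The compounds below may be only part of what the source reports. "The series", "measured", "known", "first", "only" and "open" are said of these compounds alone.

In a functional assay on CHO cells for agonist activity at Free fatty acid receptor 2 (Homo sapiens), read by cAMP accumulation (on this read-out lower numbers stand for stronger inhibition and higher numbers for weaker inhibition), compound 1 `CC(C)C(C(N)=O)c1ccc(Cl)cc1` gives only a limit, > 100000 nM. Compound 2 `CC(C)[C@H](C(=O)Nc1ccccn1)c1ccc(Cl)cc1` gives 1400 nM. Compound 3 `CC(C)(C)[C@H](C(=O)Nc1ncc(Br)s1)c1ccc(Cl)cc1` gives 700 nM, the lower of the two numbers in hand, with compound 2 within the scatter of it. Compound 4 `CSc1cnc(NC(=O)[C@H](c2ccc(Cl)cc2)C(C)(C)C)s1` differs from compound 3 by methylsulfanyl in place of bromo on an aromatic carbon, on an aromatic carbon of a five-membered aromatic ring with one nitrogen and one sulfur, next to the ring sulfur. Within the data shown here, no measured pair shows this kind of change, so no direction is supported; the expectation is a step no larger than the scatter, in either direction. Compound 4 is thus expected in this assay near 600 nM, between 200 nM and 2500 nM. The step of a 1.2-fold lower number from compound 3 to compound 4 (0.07 log units; within the scatter) is expected to be small.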

Compound 4, half-maximal inhibitory concentration: 500 nM
Beside the measured number, compound 4's estimate is 1.2-fold (0.08 log units) above it; the range from low to high includes it.
By their numbers in this assay, from the lowest: compounds 4, 3 and 2 (each within the scatter of the next, the first and the last beyond it). At a limit, above all of these: compound 1.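

In this assay, the aromatic carbon next to the ring sulfur takes methylsulfanyl in place of bromo with a 1.4-fold lower number from compound 3 to compound 4 (0.15 log units; within the scatter), so the two groups are not told apart here. This is the only one-place comparison among the compounds shown, and the hydrogen-bond acceptor that methylsulfanyl brings leaves the number within the scatter. No measurement in hand bears on the cause of this step.

Still open, as far as these compounds go, is whether an amine, a carboxylic acid or a longer chain at this carbon would move the number beyond the scatter.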